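From Cyclohexyl to Cyclopropyl on the Ring Nitrogen

The compounds below may be only part of what the source reports. "The series", "measured", "known", "first", "only" and "open" are said of these compounds alone.

Compound 1 `COc1ncc(-c2ccc3c(c2)N(c2ccc(C)cc2)C(=O)CO3)cc1NS(=O)(=O)c1ccc(F)cc1` gives 5870 nM
Compound 2 `COc1cccc(N2C(=O)COc3ccc(-c4cnc(OC)c(NS(=O)(=O)c5ccc(F)cc5)c4)cc32)c1` gives 11200 nM
Compound 3 `COc1ncc(-c2ccc3c(c2)N(C2CCCCC2)C(=O)CO3)cc1NS(=O)(=O)c1ccc(F)cc1` gives 24600 nM

All three numbers come from a functional assay on A549 cells (Homo sapiens) for antiproliferative activity, read by MTT assay, with a stated time of 72 h (a lower number here means a stronger inhibitor, a higher number a weaker inhibitor), and belong to compounds that share one core. Compound 3 stands highest of the three, which makes it the weakest inhibitor of the set. Cyclohexyl in place of 3-methoxyphenyl gave a 2.2-fold higher number from compound 2 to compound 3 (0.34 log units; beyond the scatter) and cyclohexyl in place of 4-methylphenyl gave a 4.2-fold higher number from compound 1 to compound 3 (0.62 log units; beyond the scatter) on the same nitrogen. Both steps are modest.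

The open question concerns compound 4 `COc1ncc(-c2ccc3c(c2)N(C2CC2)C(=O)CO3)cc1NS(=O)(=O)c1ccc(F)cc1` with cyclopropyl in place of cyclohexyl on an amide-type nitrogen in a ring. For the measured compounds named here, no measured step replaces one non-aromatic carbon ring with another. The two steps above show only how far cyclohexyl stands from the two substituted phenyl groups, and they say nothing direct about a smaller ring. The expectation therefore starts from compound 3 at 24600 nM and foresees no step beyond the scatter in this assay in either direction. The estimate amounts to a 1.2-fold lower number from compound 3 to compound 4 (0.09 log units; within the scatter) and is expected to be small. For compound 4 the expected value is 20000 nM with an estimated range from 8000 nM to 50000 nM as the upper end.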

Compound 4, half-maximal inhibitory concentration: 3320 nM
Compound 4: the middle estimate sits 6.0-fold (0.78 log units) above what was measured; measured number below the stated range.
By their numbers in this assay, from the lowest: compounds 4, 1 and 2 (each within the scatter of the next, the first and the last beyond it); then compound 3.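

In this assay, for the compounds shown here, the ring nitrogen proved sensitive to a change the earlier compounds did not cover, one non-aromatic carbon ring replacing another: cyclopropyl in place of cyclohexyl gave a 7.4-fold lower number from compound 3 to compound 4 (0.87 log units; beyond the scatter) and so separated two groups that differ only in ring size. Cyclopropyl in place of 3-methoxyphenyl gave a 3.4-fold lower number from compound 2 to compound 4 (0.53 log units; beyond the scatter) while cyclopropyl in place of 4-methylphenyl gave a 1.8-fold lower number from compound 1 to compound 4 (0.25 log units; within the scatter) and therefore no change that can be told from scatter, which shows that among these four compounds an aromatic ring on this nitrogen is not required for the lowest numbers, and that compound 3 with its cyclohexyl is what stands apart from compound 1. Nothing available explains why the smaller ring behaves so differently from the larger one.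

The compounds shown leave open whether cyclobutyl or cyclopentyl on this nitrogen would fall nearer compound 4 or compound 3, and so whether the number follows ring size gradually or the result belongs to cyclopropyl alone. Also open, going by these compounds, is how an open chain such as ethyl or isopropyl would compare with cyclopropyl here.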